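A Nitrophenyl Swap on the Saturated Ring Carbon

The compounds below may be only part of what the source reports. "The series", "measured", "known", "first", "only" and "open" are said of these compounds alone.

Compound 1: `COC(=O)/C(=C/c1ccccc1)CN1C(=O)[C@@H](OC)[C@H]1c1ccccc1C(F)(F)F` — 17600 nM
Compound 2: `COC(=O)/C(=C/c1ccccc1)CN1C(=O)[C@@H](OC)[C@H]1c1ccccc1` — 11100 nM

Of the compounds shown here, two have been measured in a functional assay on MDA-MB-231 cells (Homo sapiens) for antiproliferative activity, read by MTT assay, with a stated time of 48 h; a higher number here means a weaker inhibitor, a lower number a stronger inhibitor. Compound 1 gives 17600 nM and stands at the highest of the two numbers; its nearest neighbour is compound 2, which gives 11100 nM. The two differ only by hydrogen in place of trifluoromethyl on an aromatic carbon, and that step, a 1.6-fold lower number from compound 1 to compound 2 (0.20 log units; within the scatter), lies within the scatter.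

Compound 3, `COC(=O)/C(=C/c1ccccc1)CN1C(=O)[C@@H](OC)[C@H]1c1cccc([N+](=O)[O-])c1`, has not yet been measured in this assay. It differs from compound 1 as follows: 3-nitrophenyl in place of 2-(trifluoromethyl)phenyl on a saturated ring carbon. Among the compounds with values here, no measured step covers an exchange of one aryl group for another at this ring carbon; the only step at hand, from compound 1 to compound 2, shows that removing the trifluoromethyl group leaves the number essentially where it was. With nothing beyond that to rest on, the expectation for compound 3 is a number near those of compound 1 and compound 2, with no step beyond the scatter. The estimate for compound 3 is 12000 nM, within a range from 5000 nM to 35000 nM, which is expected to mean a 1.5-fold lower number from compound 1 to compound 3 (0.17 log units; within the scatter).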

Compound 3, half-maximal inhibitory concentration: 14400 nM
Estimate against measurement, compound 3: 1.2-fold (0.08 log units) below; the measured number falls inside the stated range.
By their numbers in this assay, from the lowest: compounds 2, 3 and 1 (each within the scatter of the next).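

In this assay, 3-nitrophenyl in place of 2-(trifluoromethyl)phenyl on the saturated ring carbon gives a 1.2-fold lower number from compound 1 to compound 3 (0.09 log units; within the scatter), and nitro in place of hydrogen on an aromatic carbon gives a 1.3-fold higher number from compound 2 to compound 3 (0.11 log units; within the scatter), so neither new step leaves the scatter. Within the data shown here, the earlier compounds showed only that the trifluoromethyl group could be replaced by hydrogen without a step beyond the scatter; this result extends that observation to a full exchange of one substituted aryl group for another, and to a nitro group on the plain phenyl ring, with phenyl, 2-(trifluoromethyl)phenyl and 3-nitrophenyl all giving numbers within the scatter of the next. Nothing at hand explains why these numbers stay together.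

On these data alone, all three groups at this ring carbon are phenyl rings, so it remains open whether an aminomethyl or carboxylic acid substituent on that ring, or a cyclohexyl group in place of the ring itself, would produce a step beyond the scatter. The compounds shown also leave open what a change elsewhere on the shared core would do, such as an ethoxy group in place of the methoxy group.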